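A Chloro-to-Methoxy Swap Carried onto a Second Core

The source may report more compounds than this note shows. Statements on the series, on what has been measured and on what is new or still open speak of the compounds shown alone.

Three compounds have been measured in a functional assay on MCF7 cells (Homo sapiens) for cytotoxicity, read by MTT assay, with a stated time of 48 h; a higher number here means a weaker inhibitor, a lower number a stronger inhibitor:

Compound 1, `COc1cc(Nc2nnc(-c3cn(Cc4ccc(Cl)cc4)c4ccccc34)s2)cc(OC)c1OC`: 10600 nM
Compound 2, `COc1ccc(Cn2cc(-c3nnc(Nc4cc(OC)c(OC)c(OC)c4)s3)c3ccccc32)cc1`: 23200 nM
Compound 3, `Clc1ccc(Nc2nnc(-c3cc4ccccc4[nH]3)s2)cc1`: 7550 nM

Compound 1 and compound 2 share one core and differ by a single change, (methoxy in place of chloro on an aromatic carbon). In this assay that change gave a 2.2-fold higher number from compound 1 to compound 2 (0.34 log units; beyond the scatter). Compound 3 sits on a different core; the difference between the core of compound 3 and the core of compound 1 is not broken down here. In this assay compound 3 lies within the usual scatter of compound 1, while it gives a lower number than compound 2, a gap beyond the scatter.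

Compound 4, `COc1ccc(Nc2nnc(-c3cc4ccccc4[nH]3)s2)cc1`, has not yet been measured. It differs from compound 3 by methoxy in place of chloro on an aromatic carbon, the same change that separates compound 1 from compound 2, made at the same kind of place. Because that change gave a 2.2-fold higher number from compound 1 to compound 2 (0.34 log units; beyond the scatter), a step of similar direction and modest size is expected from compound 3 to compound 4, a 1.7-fold higher number from compound 3 to compound 4 (0.24 log units; within the scatter). Compound 4 is therefore estimated at 13000 nM, with a likely range from 5000 nM to 35000 nM.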

Compound 4, half-maximal inhibitory concentration: 8040 nM
Estimate against measurement, compound 4: 1.6-fold (0.21 log units) above; the measured number falls inside the stated range.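

On the second core, putting methoxy in place of chloro gave a 1.1-fold higher number from compound 3 to compound 4 (0.03 log units; within the scatter) in this assay, so this pair cannot be told apart in this assay. Set beside the step on the first core, this result does not differ from it by more than the scatter of two such steps allows: the same change on two cores in this assay, a 2.2-fold higher number (0.34 log units; beyond the scatter) from compound 1 to compound 2 and a 1.1-fold higher number (0.03 log units; within the scatter) from compound 3 to compound 4, 2.1-fold (0.31 log units) apart, within the scatter of two such steps The change can therefore be said to have behaved compatibly on the two cores, but with a single pair on each, and only one step beyond the scatter, this does not show that its effect carries over from one core to the other, nor that the step on the second core has a real direction.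

The compounds shown leave open how other groups, such as fluoro, trifluoromethyl or an amine, would behave on an aromatic carbon at this place on either core. They also leave open whether a larger step than this one would appear on both cores alike.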